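Working notes on cytotoxicity across the series

This account rests on a few compounds, and the source may have more. Where it says the series, first, only, none or still open, it means among the compounds named here.

Compound 3 `COC(=O)c1ccc(NCc2cncn2Cc2ccc(-c3ccccc3)cc2)cc1-c1ccccc1` was tested in a toxicity assay on NIH3T3 cells (Mus musculus) for cytotoxicity, read by resazurin assay (a higher number here means that more compound is needed for the effect, a lower number that less compound is needed), where it reaches only a limit of the assay: compound 3 gives > 1000 nM. Compound 1 `CCC(=O)c1ccc(NCc2cncn2Cc2ccc(-c3ccccc3)cc2)cc1-c1ccccc1` likewise sits at a limit; in this assay compound 1 gives > 10000 nM. Compound 2 `CCOC(=O)c1ccc(NCc2cncn2Cc2ccc(-c3ccccc3)cc2)cc1-c1ccccc1` also stands at a limit, and in this assay compound 2 gives > 10000 nM. The steps among these three are consequently not readable: a step that the two limits leave unreadable from compound 1 to compound 2, a step that the two limits leave unreadable from compound 1 to compound 3 and a step that the two limits leave unreadable from compound 2 to compound 3 all remain unresolved, which the limit of > 1000 nM in this assay, at which 1 of the 3 values shown sits, and the limit of > 10000 nM in this assay, at which 2 of the 3 values shown sit, record.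

Compound 4 `COC(=O)c1ccc(NCc2cncn2Cc2ccccc2[N+](=O)[O-])cc1-c1ccccc1` has not yet been measured. The change from compound 3 is 2-nitrophenyl in place of 4-phenylphenyl on a saturated chain carbon bound to an aromatic nitrogen. Within the data shown here, no measured step touches this position; the three known steps alter only the group on the carbonyl carbon, and none of them yields a number. Nothing in the series therefore sets a direction or a size for this step, and the most that can be said is that a further limit is the likeliest report. For compound 4 the expected value in this assay is 10000 nM, with a range from 2000 nM to 50000 nM. The step this implies, a step that the limit leaves unreadable from compound 3 to compound 4, is expected to stay within the scatter, and a limit rather than a number is anticipated.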

Compound 4, half-maximal effective concentration: 10000 nM
Compound 4: middle estimate and measured number agree at the digits printed; low and high end bracket the measured number.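

In this assay compound 3 gives > 1000 nM, which is a limit of the assay. Compound 4 gives 10000 nM, and the step from compound 3 to compound 4 cannot be read. The compounds shown leave open whether 2-nitrophenyl in place of 4-phenylphenyl on a saturated chain carbon bound to an aromatic nitrogen changes cytotoxicity at all.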